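The compounds below may be only part of what the source reports. "The series", "measured", "known", "first", "only" and "open" are said of these compounds alone.

Of the compounds shown here, three have been measured in an ADME assay on J774.A1 cells (Mus musculus) for cytotoxicity, read by MTT assay, with a stated time of 72 h; on this read-out lower numbers stand for higher toxicity in this test and higher numbers for lower toxicity in this test.

Compound 1 `CC1(c2ccc(-c3ccccc3C#N)cc2)CC(S(=O)(=O)c2ccc(F)cc2)=C(c2ccc(/C(N)=N\O)cc2)O1` gives 9290 nM.
Compound 2 `CCC1(c2ccccc2OC)CC(S(=O)(=O)c2ccc(F)cc2)=C(c2ccc(/C(N)=N\O)cc2)O1` gives 9880 nM.
Compound 3 `CC1(Cc2ccccc2)CC(S(=O)(=O)c2ccc(F)cc2F)=C(c2ccc(/C(N)=N\O)cc2)O1` gives 41500 nM.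

Compound 1 gives the lowest number of the three, but compound 2 sits within the usual scatter of it, so the two cannot be ranked; compound 3 lies beyond the scatter, at a higher number, meaning lower toxicity in this assay. No two of the measured compounds differ in only one place, so no single-step comparison is available.

Compound 4 `CC1(c2ccc(-c3cccc([N+](=O)[O-])c3)cc2)CC(S(=O)(=O)c2ccc(F)cc2)=C(c2ccc(/C(N)=N\O)cc2)O1` differs from compound 1 by 3-nitrophenyl in place of 2-cyanophenyl on an aromatic carbon. Without a measured step of this kind, the change expected in this assay is small, within the scatter, a shift of a 1.1-fold higher number from compound 1 to compound 4 (0.03 log units; within the scatter) in either direction. Compound 4 is therefore estimated at 10000 nM, with a range from 4000 nM to 25000 nM.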

Compound 4, half-maximal cytotoxic concentration: 11100 nM
Estimate against measurement, compound 4: 1.1-fold (0.05 log units) below, within the range that was stated.
By their numbers in this assay, from the lowest: compounds 1, 2 and 4 (each within the scatter of the next); then compound 3.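

In this assay, for the compounds shown here, the exchange of 2-cyanophenyl for 3-nitrophenyl gives a 1.2-fold higher number from compound 1 to compound 4 (0.08 log units; within the scatter) and is the first single-place change. At this aromatic carbon, para to a large group, one substituted phenyl ring can thus stand in for another with no shift beyond the usual scatter. Nothing measured here accounts for this result.

The compounds shown leave open what an amine or a carboxylic acid on this ring would do. They also leave open whether an unsubstituted phenyl ring would give a similar number.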